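Aryl swap on the fused core: from ethyl to difluoro

The source may hold more compounds than are shown below. What is called first, only, known or untested is meant among the compounds shown, and "the series" means these compounds.

Measured compounds:
compound 1, `CC#CC(CC(=O)O)c1ccc(OCc2ccc3nc(-c4ccc(CC)cc4)cn3c2)cc1`, 496 nM
compound 2, `CC#CC(CC(=O)O)c1ccc(OCc2ccc3nc(-c4ccc(C(F)(F)F)cc4)cn3c2)cc1`, 558 nM
compound 3, `CC#CC(CC(=O)O)c1ccc(OCc2ccn3cc(-c4ccc(CC)cc4)nc3c2)cc1`, 671 nM

All three share the same acid-bearing side chain and differ only in the fused core and in the phenyl group on it. In an assay on isolated protein for agonist activity at Free fatty acid receptor 1 (Homo sapiens) (on this read-out lower numbers stand for an effect already at smaller amounts and higher numbers for an effect only at larger amounts of compound), compound 3 gives 671 nM, and compound 1 gives 496 nM while compound 2 gives 558 nM; the gaps among the three lie within the scatter, so none of them stands apart from the others.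

Compound 4, `CC#CC(CC(=O)O)c1ccc(OCc2ccn3cc(-c4cc(F)ccc4F)nc3c2)cc1`, has not been measured in this assay. It differs from compound 3 in one place: 2,5-difluorophenyl in place of 4-ethylphenyl on an aromatic carbon. Among the compounds with values here, the only step between measured compounds that touches the same phenyl ring is a 1.1-fold higher number from compound 1 to compound 2 (0.05 log units; within the scatter), a para exchange on a different core, which hardly moved the number. Within the data shown here, the change to compound 4 is of another kind, with two fluorines in a new pattern, and no measured pair shows its effect. Compound 3 is therefore taken as the anchor, and compound 4 is expected to land close to it, with a small shift toward a higher number and wide uncertainty, as a 1.3-fold higher number from compound 3 to compound 4 (0.13 log units; within the scatter). The estimate for compound 4 is 900 nM, with a range from 350 nM to 2500 nM.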

Compound 4, half-maximal effective concentration: 639 nM
Estimate against measurement, compound 4: 1.4-fold (0.15 log units) above; low and high end bracket the measured number.
By their numbers in this assay, from the lowest: compounds 1, 2, 4 and 3 (each within the scatter of the next).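

On the core of compound 3, at the aromatic carbon of the five-membered aromatic ring next to the ring nitrogen, replacing 4-ethylphenyl with 2,5-difluorophenyl gives a 1.1-fold lower number from compound 3 to compound 4 (0.02 log units; within the scatter) in this assay. The earlier step on this phenyl ring, a 1.1-fold higher number from compound 1 to compound 2 (0.05 log units; within the scatter), exchanged one group for another on the core of compound 1, whereas this change removes the ethyl group and brings in two fluorines, and the result shows that the all-carbon 4-ethylphenyl is not needed on this core to give a number in the same range. Nothing measured here explains this result.

The compounds shown leave open whether a phenyl ring carrying an amine or a methoxy group would also fall within this range. They also leave open how 2,5-difluorophenyl would read on the core of compound 1.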